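Fluoro-methylphenyl variant of an arylidene piperazinedione scaffold

The source may report more compounds than this note shows. Statements on the series, on what has been measured and on what is new or still open speak of the compounds shown alone.

Compound 1 `C=CCn1c(=O)/c(=C\c2cccc(Cl)c2)[nH]c(=O)/c1=C\c1ccccc1OC` gives 4600 nM in a functional assay on BGC-823 cells (Homo sapiens) for cytotoxicity, read by CCK-8 assay, with a stated time of 72 h; on this read-out lower numbers stand for stronger inhibition and higher numbers for weaker inhibition. Compound 2 `C=CCn1c(=O)/c(=C\c2cc(Br)ccc2F)[nH]c(=O)/c1=C\c1ccccc1OC` is reported as "not active" (no number reported) in this assay. Compound 3 `C=CCn1c(=O)/c(=C\c2ccc(C)cc2)[nH]c(=O)/c1=C\c1ccccc1OC` is likewise reported as "not active" (no number reported) in this assay, so no single number stands for compound 3, and compound 2 is a further entry without a number. Compound 4 `C=CCn1c(=O)/c(=C\c2cc(F)ccc2C)[nH]c(=O)/c1=C\c1ccccc1OC` differs from compound 3 by 5-fluoro-2-methylphenyl in place of 4-methylphenyl on a double-bonded chain carbon bound to an aromatic carbon. With compound 3 not giving a number, the size of the step to compound 4 in this assay cannot be stated from the shown data; the expectation is that compound 4 will not move beyond the scatter into a measurably strong result. Compound 4 is therefore estimated at 20000 nM in this assay, within a range from 5000 nM to 80000 nM, with a real chance that only a limit is reported.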

Compound 4, half-maximal inhibitory concentration: 1600 nM
Beside the measured number, compound 4's estimate is 13-fold (1.10 log units) above it, and the stated range ends above it.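

With 5-fluoro-2-methylphenyl on the double-bonded chain carbon bound to an aromatic carbon, compound 4 gives a number in this assay, whereas compound 3, with 4-methylphenyl, gives none, so the step between them cannot be read. Replacing 3-chlorophenyl gives a 2.9-fold lower number from compound 1 to compound 4 (0.46 log units; beyond the scatter), showing that a change at this place can shift the number beyond the scatter. Nothing shown accounts for this result. The compounds shown leave open whether the fluorine or the methyl carries the step, and how an amine or a carboxylic acid in place of the fluorine would read.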